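A few compounds are considered here, and "the series" means these few. Any claim that something is new, unique, unknown or untested is made for them only; others in the source may bear on it.

Of the compounds shown here, two have been measured in an assay on CHO cells for displacement of a labelled ligand from prostaglandin D2 receptor 2 (Homo sapiens), read by scintillation counting; a lower number here means a stronger inhibitor, a higher number a weaker inhibitor. Compound 1 `CCCS(=O)(=O)c1cccc(C#Cc2cc(Cl)ccc2OCC(=O)O)c1` gives 9 nM in this assay, and compound 2 `O=C(O)COc1ccc(Cl)cc1C#Cc1ccc(CO)cc1F` gives 28 nM. Of these two numbers, compound 1 has the lower one, and the gap between compound 1 and compound 2 lies beyond the usual scatter of repeated measurements, so compound 1 is the stronger inhibitor of the pair. For the measured compounds named here, no pair of measured compounds differs in only one place, so no single change has yet been followed from one number to another.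

Compound 3 `CN(c1cccc(C#Cc2cc(Cl)ccc2OCC(=O)O)c1)S(C)(=O)=O` has not yet been measured. It differs from compound 1 in one place: methyl(methylsulfonyl)amino in place of propylsulfonyl on an aromatic carbon. The group that leaves and the group that enters are counted as equal in size and in hydrogen-bond acceptors, and both carry the same sulfonyl unit. Going by the values given here, with no measured step of this kind to lean on, the expectation rests on that similarity alone. A step from compound 1 to compound 3 of a 2.2-fold higher number from compound 1 to compound 3 (0.35 log units; beyond the scatter) is expected in this assay, a change within or close to the usual scatter, leaning towards a slightly higher number. Compound 3 is therefore estimated at 20 nM in this assay, with a likely range from 5 nM to 80 nM.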

Compound 3, inhibition constant: 122 nM
The estimate for compound 3 lay 6.1-fold (0.79 log units) below the measured number, and the stated range ends below it.
By their numbers in this assay, from the lowest: compound 1; then compound 2; then compound 3.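

Putting methyl(methylsulfonyl)amino in place of propylsulfonyl, on an aromatic carbon meta to a large group, gives a 14-fold higher number from compound 1 to compound 3 (1.13 log units; beyond the scatter) in this assay, so binding in this assay clearly distinguishes between these two groups at this position. Equal counts of heavy atoms and hydrogen-bond acceptors and a shared sulfonyl unit therefore do not make the groups interchangeable here; the entering group has a nitrogen that the leaving group lacks, and one carbon fewer. No measurement is available that explains the size of this step.

With only this one step at the position, the compounds shown cannot separate the contribution of the added nitrogen from that of the change in the carbon part, and compound 2 differs from the other two compounds in more than one place, so it cannot settle the matter. On these data alone, it also remains open where a shorter ethylsulfonyl group, or a methylsulfonylamino group that keeps its hydrogen on the nitrogen, would fall relative to these two groups.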